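Amino(sulfanyl)methyl in Place of 4-Fluorophenyl on an Amine Nitrogen

The source may report more compounds than this note shows. Statements on the series, on what has been measured and on what is new or still open speak of the compounds shown alone.

Compound 1, `Nc1nn2c(O)cc(CCl)nc2c1[N+](=O)[O-]`, in a functional assay on K562 cells (Homo sapiens) for inhibition; on this read-out lower numbers stand for stronger inhibition of growth and higher numbers for weaker inhibition of growth: > 50 ug/mL
Compound 2, `Nc1nn2c(O)cc(CNNc3ccc(F)cc3)nc2c1[N+](=O)[O-]`, in this assay : 19.7 ug/mL

The value of compound 1 is a limit of the assay, not a number (the limit of > 50 ug/mL in this assay, at which 1 of the 2 values shown sits). Within the data shown here, compound 2 therefore stands as the only measured number in the set, and no step between two measured compounds can be drawn from these two values. Compound 3, `Nc1nn2c(O)cc(CNNC(N)S)nc2c1[N+](=O)[O-]`, keeps the shared core of compound 2 and differs from it in one place: amino(sulfanyl)methyl in place of 4-fluorophenyl on an amine nitrogen. Among the measured compounds shown here, with no measured step to lean on, the size and direction of this change cannot be read from the data, and the expectation for compound 3 is anchored only to the number of compound 2. Compound 3 is expected to give 30 ug/mL, within 10 ug/mL to 80 ug/mL, which corresponds to an expected step of a 1.5-fold higher number from compound 2 to compound 3 (0.18 log units; within the scatter), not clearly beyond the usual scatter.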

Compound 3, concentration for 50% growth inhibition: > 50 ug/mL
Compound 3: no number, only a limit; the forecaster's own chance of this, stated with the estimate: 35%; middle value at least 1.6-fold (0.22 log units) away from the limit.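

Amino(sulfanyl)methyl in place of 4-fluorophenyl on an amine nitrogen gives in this assay an at least 2.5-fold higher number from compound 2 to compound 3 (0.40 log units; beyond the scatter) as the first readable step in the set, and its size is only a minimum. The value of compound 3 is a limit of the assay and not a number, and the set now holds two such values: the limit of > 50 ug/mL in this assay, at which 2 of the 3 values shown sit. Among these compounds, on this amine nitrogen, the 4-fluorophenyl of compound 2 thus goes with the only measured number in the set, while the step from compound 1 to compound 3 cannot be read.

From the compounds shown here alone, how far the true value of compound 3 lies past its limit stays open. Going by these compounds, it is also open whether the number of compound 2 depends on the aromatic ring or on its fluorine, which a plain phenyl on the same amine nitrogen would help to separate.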